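The source may report more compounds than this note shows. Statements on the series, on what has been measured and on what is new or still open speak of the compounds shown alone.

Measured compounds:
compound 1, `Cc1ccc(CNC(=O)c2cccc(C(C)Oc3ccnc(Nc4cnn(C5CCN(C)CC5)c4)c3)c2)cc1`, 8100 nM
compound 2, `CC(Oc1ccnc(Nc2cnn(C3CCN(C)CC3)c2)c1)c1cccc(C(=O)NCc2ccc(Cl)c(C(F)(F)F)c2)c1`, 7300 nM
compound 3, `Cc1ccc(CNC(=O)c2cccc(C(C)Oc3ccnc(NN4CCN(C)CC4)c3)c2)cc1`, 26200 nM

These three were tested in a functional assay on HCC78 cells (Homo sapiens) for antiproliferative activity, read by MTT assay, with a stated time of 48 h; a lower number here means a stronger inhibitor, a higher number a weaker inhibitor. Compound 2 differs from compound 1 by one change, (4-chloro-3-(trifluoromethyl)phenyl in place of 4-methylphenyl on a saturated chain carbon bound to an amide-type nitrogen), and this gave a 1.1-fold lower number from compound 1 to compound 2 (0.05 log units; within the scatter). Compound 3 differs from compound 1 in its core: 4-methylpiperazin-1-yl in place of 1-(1-methylpiperidin-4-yl)-1H-pyrazol-4-yl on a nitrogen on an aromatic ring, which gave a 3.2-fold higher number from compound 1 to compound 3 (0.51 log units; beyond the scatter), so compound 3 gives the highest number of the three in this assay.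

Compound 4, `CC(Oc1ccnc(NN2CCN(C)CC2)c1)c1cccc(C(=O)NCc2ccc(Cl)c(C(F)(F)F)c2)c1`, has not yet been measured. It stands to compound 3 as compound 2 stands to compound 1: the change is 4-chloro-3-(trifluoromethyl)phenyl in place of 4-methylphenyl on a saturated chain carbon bound to an amide-type nitrogen, and the place is described in the same words for both pairs, so it is the same change, now made on the core of compound 3 rather than that of compound 1. Because the earlier step was a 1.1-fold lower number from compound 1 to compound 2 (0.05 log units; within the scatter), compound 4 is expected to sit close to compound 3, with an estimated step of a 1.1-fold lower number from compound 3 to compound 4 (0.04 log units; within the scatter). For compound 4 the estimate in this assay is 24000 nM, expected to fall between 10000 nM and 60000 nM.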

Compound 4, half-maximal inhibitory concentration: 23500 nM
Estimate against measurement, compound 4: 1.0-fold (0.01 log units) above; measured number inside the range.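

In this assay, putting 4-chloro-3-(trifluoromethyl)benzyl in place of 4-methylbenzyl gave a 1.1-fold lower number from compound 3 to compound 4 (0.05 log units; within the scatter), and the same change on the other core gave a step of matching size: the same change on two cores in this assay, a 1.1-fold lower number (0.05 log units; within the scatter) from compound 1 to compound 2 and a 1.1-fold lower number (0.05 log units; within the scatter) from compound 3 to compound 4, 1.0-fold (0.00 log units) apart, within the scatter of two such steps. Putting 4-methylpiperazin-1-yl in place of 1-(1-methylpiperidin-4-yl)-1H-pyrazol-4-yl on a nitrogen on an aromatic ring gave a 3.2-fold higher number from compound 2 to compound 4 (0.51 log units; beyond the scatter), which also matches its earlier counterpart: the same change on two cores in this assay, a 3.2-fold higher number (0.51 log units; beyond the scatter) from compound 1 to compound 3 and a 3.2-fold higher number (0.51 log units; beyond the scatter) from compound 2 to compound 4, 1.0-fold (0.00 log units) apart, within the scatter of two such steps. Across these four compounds, each change therefore carried over from one core to the other, but each comparison rests on only one pair of steps, the benzyl change stays within the scatter on both cores, and nothing here explains why the steps match or shows that a benzyl change with a larger effect would carry over as well.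

On these data alone, it remains open whether the same agreement would hold for a different group on the amide nitrogen, such as an unsubstituted benzyl or a longer chain ending in a carboxylic acid. As far as these compounds go, it also remains open how a morpholine in place of 4-methylpiperazin-1-yl would behave on either core.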